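The compounds below may be only part of what the source reports. "The series", "measured", "known", "first", "only" and "open" are said of these compounds alone.

Of the compounds shown here, two have been tested in an assay on FRT-Jurkat cells for inhibition of nuclear factor NF-kappa-B complex (Homo sapiens), read by flow cytometry, with a stated time of 24 h, tested at 10 uM (a lower number here means less inhibition, a higher number more inhibition at the concentration tested (going by the name of the read-out)), so far. Compound 1 `O=C1CCC(N2C(=O)c3ccc(Nc4ccccn4)cc3C2=O)C(=O)N1` gives 9% in this assay. Compound 2 `O=C1CCC(N2C(=O)c3cccc(Nc4ccccc4)c3C2=O)C(=O)N1` gives 4% in this assay, the lower of the two numbers; the gap to compound 1 lies within the scatter of repeated measurements, so the two readings cannot be told apart.

Compound 3 `COc1ccc(Nc2cccc3c2C(=O)N(C2CCC(=O)NC2=O)C3=O)cc1` is the next compound for this assay. It differs from compound 2 in one place: methoxy in place of hydrogen on an aromatic carbon, on an aromatic carbon of a six-membered aromatic ring of carbon only. Among the compounds with values here, no measured pair shows such a change, and both numbers in hand sit low. The step of a number 4 percentage points higher from compound 2 to compound 3 (within the scatter) is therefore expected to stay within the scatter, in no particular direction. For compound 3 the estimate in this assay is 8%, with a range from -6% to 24%.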

Compound 3, a percentage reported as inhibition, at one concentration (the size of the read-out at that concentration, not a potency): 13%
Compound 3: middle estimate off by 5 percentage points, on the low side, and the stated range covers the measured number.
By their numbers in this assay, from the lowest: compounds 2, 1 and 3 (each within the scatter of the next).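

In this assay, methoxy in place of hydrogen on the six-membered aromatic ring of carbon only, para to a large group, gives a number 9 percentage points higher from compound 2 to compound 3 (within the scatter). Within the data shown here, this is the first single-place change that can be read, and phenyl to 4-methoxyphenyl does not separate compound 3 from compound 2, so this position accepts the methoxy group without a change that can be told from the scatter. No supporting data bear on this reading, which leaves it without an explanation.

On these data alone, whether any group at this position can move the number beyond the scatter remains open, for example an amine, a carboxylic acid or a longer chain such as butoxy. Also open, as far as these compounds go, is whether a reading well above these low numbers can be reached on the shared core at all.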